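The source may hold more compounds than are shown below. What is called first, only, known or untested is meant among the compounds shown, and "the series" means these compounds.

Of the compounds shown here, two with a shared core have been measured in a functional assay on PC-3 cells (Homo sapiens) for inhibition; a lower number here means a stronger inhibitor, a higher number a weaker inhibitor. Compound 1, with structure `COc1cc2nc(N3CCN(S(=O)(=O)c4ccc([N+](=O)[O-])cc4)CC3)nc(N)c2cc1OC`, gives 36000 nM in this assay. Among the measured compounds shown here, compound 2, with structure `COc1cc2nc(N3CCN(S(=O)(=O)c4ccc(S(C)(=O)=O)cc4)CC3)nc(N)c2cc1OC`, gives 17000 nM in this assay, which is the lowest of the two numbers, the step of a 2.1-fold lower number from compound 1 to compound 2 (0.33 log units; beyond the scatter) being the only comparison available.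

Compound 3, with structure `COc1cc2nc(N3CCN(S(=O)(=O)c4cccc(C(=O)O)c4)CC3)nc(N)c2cc1OC`, has not yet been measured. It differs from compound 2 by 3-carboxyphenyl in place of 4-(methylsulfonyl)phenyl on a sulfonyl sulfur. For the measured compounds named here, the only step that bears on this change is a 2.1-fold lower number from compound 1 to compound 2 (0.33 log units; beyond the scatter), in which the substituent on the same aromatic ring was exchanged and the number moved by a modest amount. The change to compound 3 is larger in kind, since the acid enters at a different position of the ring and brings a hydrogen-bond donor, so a step of similar size in either direction is expected for this assay, with no strong reason to favour a lower number.

Compound 3 is therefore expected to give about 25000 nM in this assay, within a range from 8000 nM to 80000 nM. This estimate means a step of a 1.5-fold higher number from compound 2 to compound 3 (0.17 log units; within the scatter), expected to stay close to the scatter.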

Compound 3, half-maximal inhibitory concentration: 53000 nM
Compound 3: middle estimate off by 2.1-fold (0.33 log units), on the low side; the measured number falls inside the stated range.
By their numbers in this assay, from the lowest: compound 2; then compounds 1 and 3 (each within the scatter of the next).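

In this assay, 3-carboxyphenyl in place of 4-(methylsulfonyl)phenyl on the sulfonyl sulfur gives a 3.1-fold higher number from compound 2 to compound 3 (0.49 log units; beyond the scatter), a modest step towards weaker inhibition that shows this position does not accept every aromatic group equally. Replacing 4-nitrophenyl with the same group gives a 1.5-fold higher number from compound 1 to compound 3 (0.17 log units; within the scatter), so this assay does not separate 3-carboxyphenyl from 4-nitrophenyl, and compound 2 stands as the strongest inhibitor of the three, with its steps to both others beyond the scatter. No measurement is available that would explain why these groups differ or match.

The change from compound 2 to compound 3 alters both the substituent and where it sits on the aromatic ring, so these compounds cannot show how much of the step belongs to each. As far as these compounds go, compound 2 gives 17000 nM, and it remains open whether a different group, such as an amine on the aromatic ring or a simple alkyl chain on the sulfonyl sulfur in place of the ring, would take the number much lower.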